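Series notes: tert-butyl in place of methyl on the core

The source may hold more compounds than are shown below. What is called first, only, known or untested is meant among the compounds shown, and "the series" means these compounds.

Compound 1 `Cc1cc(N2CCNCC2)c2c(c1)N(S(=O)(=O)c1ccccc1F)CCO2` gives 0.398 nM in an assay on HEK293 cells for displacement of a labelled ligand from 5-hydroxytryptamine receptor 6 (Homo sapiens) (on this read-out higher numbers stand for weaker inhibition and lower numbers for stronger inhibition), level with compound 3 `COc1cc(N2CCNCC2)c2c(c1)N(S(=O)(=O)c1ccccc1)CCO2`, which gives 0.398 nM; together they stand lowest of the three numbers. Compound 2 `Cc1cc(N2CCNCC2)c2c(c1)N(S(=O)(=O)c1ccccc1C#N)CCO2` gives 2 nM, and the step of a 5.0-fold higher number from compound 1 to compound 2 (0.70 log units; beyond the scatter) follows cyano in place of fluoro on an aromatic carbon. The step to compound 4 `CC(C)(C)c1cc(N2CCNCC2)c2c(c1)N(S(=O)(=O)c1ccccc1F)CCO2` is of another kind: tert-butyl in place of methyl on an aromatic carbon. Among the compounds with values here, no measured pair changes only this position; compounds 1 and 3 differ there but also elsewhere, so their matching values settle nothing about it. Within the data shown here, with no step bearing on the change, a modest weakening is expected for compound 4, a 2.5-fold higher number from compound 1 to compound 4 (0.40 log units; beyond the scatter), giving an estimate of 1 nM with a range of 0.2 nM to 5 nM.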

Compound 4, inhibition constant: 7.94 nM
Compound 4: the middle estimate sits 7.9-fold (0.90 log units) below what was measured; the measured number lies above the stated range.
By their numbers in this assay, from the lowest: compounds 1 and 3 (each within the scatter of the next); then compound 2; then compound 4.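

Within the data shown here, this is the first pair that changes only this position, and in this assay the change from methyl to tert-butyl on the aromatic carbon gives a 20-fold higher number from compound 1 to compound 4 (1.30 log units; beyond the scatter). The position is therefore not indifferent to its substituent, at least with the 2-fluorophenyl sulfonyl group held constant. No measurement on hand accounts for the step. On these data alone, whether the step would persist with a different sulfonyl aryl group remains open. Also open, as far as these compounds go, is how ethyl, isopropyl or an amine on this aromatic carbon would read against methyl and tert-butyl.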